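Replacing the aryl on a triple-bonded carbon: compound 4

The source may hold more compounds than are shown below. What is called first, only, known or untested is meant among the compounds shown, and "the series" means these compounds.

Three analogues of one core have been measured in an assay on CHO cells for displacement of a labelled ligand from adenosine receptor A1 (Homo sapiens), read by scintillation counting, with a stated time of 60 min, tested at 10 uM; on this read-out higher numbers stand for more inhibition at the one concentration tested (going by the name of the read-out) and lower numbers for less inhibition. Compound 3 `CNC(=O)[C@@]12C[C@@H]1[C@@H](n1cnc3c(NC)nc(C#Cc4ccc(CO)cc4)nc31)[C@H](O)[C@@H]2O` gives 16% in this assay and stands second highest of the three numbers. Its nearest neighbour is compound 1 `CNC(=O)[C@@]12C[C@@H]1[C@@H](n1cnc3c(NC)nc(C#Cc4ccccc4F)nc31)[C@H](O)[C@@H]2O` with 20%, its furthest compound 2 `CNC(=O)[C@@]12C[C@@H]1[C@@H](n1cnc3c(NC)nc(C#Cc4ccc(OC)cc4)nc31)[C@H](O)[C@@H]2O` with 10%; both gaps lie within the scatter, so the three numbers cannot be ordered.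

Compound 4 `CCc1ccc(C#Cc2nc(NC)c3ncn([C@H]4[C@H](O)[C@H](O)[C@]5(C(=O)NC)C[C@H]45)c3n2)o1` differs from compound 3 in one place: 5-ethylfuran-2-yl in place of 4-(hydroxymethyl)phenyl on a triple-bonded carbon. Within the data shown here, the steps that bear on this position all moved the same substituent on a triple-bonded carbon: a number 4 percentage points lower from compound 1 to compound 3 (within the scatter), a number 10 percentage points lower from compound 1 to compound 2 (within the scatter) and a number 6 percentage points higher from compound 2 to compound 3 (within the scatter). None of these changes went beyond the scatter, although they swapped a fluorophenyl, a methoxyphenyl and a hydroxymethylphenyl. A five-membered aromatic ring with an ethyl substituent has not been tried here, so the new ring is untested ground, but the measured record gives no reason to expect a step beyond the scatter; the expected step is a number 1 percentage points lower from compound 3 to compound 4 (within the scatter). The estimate for compound 4 in this assay is 15%, with a range from 5% to 27%.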

Compound 4, a percentage reported as inhibition, at one concentration (the size of the read-out at that concentration, not a potency): 18%
Compound 4: the middle estimate sits 3 percentage points below what was measured; low and high end bracket the measured number.
By their numbers in this assay, from the lowest: compounds 2, 3, 4 and 1 (each within the scatter of the next).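

In this assay a five-membered aromatic ring with one hetero atom now stands on the triple-bonded carbon, and every swap to 5-ethylfuran-2-yl stays within the scatter: the swap for 4-(hydroxymethyl)phenyl reads (a number 2 percentage points higher from compound 3 to compound 4 (within the scatter)), the swap for 4-methoxyphenyl (a number 8 percentage points higher from compound 2 to compound 4 (within the scatter)) and the swap for 2-fluorophenyl (a number 2 percentage points lower from compound 1 to compound 4 (within the scatter)). Neither ring size nor the hydrogen-bond donor of the hydroxymethyl group separates compounds at this position, so all four numbers remain unordered. Nothing at hand accounts for this flat picture.

Going by these compounds, whether an amine, a carboxylic acid or a longer chain in place of the aromatic ring would move the number beyond the scatter stays open. So does whether the four compounds would separate in a read-out of potency rather than inhibition at one concentration.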